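Amide series: a cyanophenyl replacement in the biaryl arm

The source may hold more compounds than are shown below. What is called first, only, known or untested is meant among the compounds shown, and "the series" means these compounds.

Measured in a functional assay on SK-OV-3 cells (Homo sapiens) for antiproliferative activity, read by MTT assay, with a stated time of 72 h; a higher number here means a weaker inhibitor, a lower number a stronger inhibitor:
compound 1, `CC(C)(C)OC(=O)NCc1ccc(NC(=O)CCc2cccc3c2B(O)OC3)cc1`, gives 2000 nM.
compound 2, `O=C(CCc1cccc2c1B(O)OC2)Nc1cccc(-c2ccc(F)cc2)c1`, gives 93 nM.
compound 3, `O=C(CCc1cccc2c1B(O)OC2)Nc1cccc(-c2ccc(OC(F)(F)F)cc2)c1`, gives 560 nM.

Compound 2 stands lowest of the three numbers in this assay; its nearest neighbour is compound 3, and compound 1 lies furthest from it. Among the measured compounds shown here, only one single-point step is on record, a 6.0-fold higher number from compound 2 to compound 3 (0.78 log units; beyond the scatter), which exchanges a group on the distal ring of the biaryl arm. Compound 4, `N#Cc1cccc(-c2cccc(NC(=O)CCc3cccc4c3B(O)OC4)c2)c1`, differs from compound 2 by 3-cyanophenyl in place of 4-fluorophenyl on an aromatic carbon. This is a change of the whole distal ring rather than of one substituent on it, so the measured step from compound 2 to compound 3 bears on it only loosely; it does show that altering the distal ring of compound 2 in this assay can move the number by a modest amount, and in the weakening direction. For the measured compounds named here, no other measured pair informs the shift from a fluoro to a nitrile, nor the move of the substituent on that ring. The expectation for compound 4 is therefore a modest step in the weakening direction, a 2.7-fold higher number from compound 2 to compound 4 (0.43 log units; beyond the scatter), with wide uncertainty. Compound 4 is estimated at 250 nM, within 80 nM to 800 nM.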

Compound 4, half-maximal inhibitory concentration: 120 nM
Beside the measured number, compound 4's estimate is 2.1-fold (0.32 log units) above it; measured number inside the range.
By their numbers in this assay, from the lowest: compounds 2 and 4 (each within the scatter of the next); then compound 3; then compound 1.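

In this assay, 3-cyanophenyl in place of 4-fluorophenyl on an aromatic carbon gives a 1.3-fold higher number from compound 2 to compound 4 (0.11 log units; within the scatter), so these two compounds cannot be ranked against each other. Among the compounds shown here, until now, the only single-point evidence on this distal ring was a 6.0-fold higher number from compound 2 to compound 3 (0.78 log units; beyond the scatter), which left open whether other alterations there would also raise the number; this new step shows that replacing the whole ring, including a nitrile that brings the hydrogen-bond acceptor counted for the entering group, need not do so. No measured information accounts for the difference between these two steps.

The compounds shown do not separate the contribution of the nitrile from that of its place on the ring, a question that 4-cyanophenyl and 3-fluorophenyl analogues would address directly. Also open, from the compounds shown here alone, is how the number responds to quite different groups on this ring, such as an amine or a carboxylic acid, which would test whether the flat response seen here extends beyond the nitrile.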